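Acid to Alcohol on an Aminohydroxy Chain

This account rests on a few compounds, and the source may have more. Where it says the series, first, only, none or still open, it means among the compounds named here.

Measured compounds:
compound 1, `COC(=O)CCCCCCCCC(O)CN`, 29800 nM
compound 2, `NCC(O)CCCCCCCCC(=O)O`, "not active" (no number reported)

In a functional assay on MDA-MB-231 cells (Homo sapiens) for cytotoxicity, read by MTT assay (on this read-out lower numbers stand for stronger inhibition and higher numbers for weaker inhibition), compound 1 gives 29800 nM. Compound 2 is reported in this assay as "not active" (no number reported), so no number places it on the scale; compound 2 stands apart as the compound for which no inhibition at all was recorded, while compound 1 at least reaches a weak value. Compound 3, `NCC(O)CCCCCCCCCO`, has not yet been tested. It differs from compound 2 by hydroxymethyl in place of carboxy on a saturated chain carbon, nine bonds along the chain from an oxygen on a saturated carbon. Within the data shown here, no step between measured compounds is available, so the size of this change cannot be read from a neighbouring pair. Among the measured compounds shown here, the two measured compounds show only that the free carboxy compound gives nothing and the other gives a weak value, so for compound 3 a weak result in this assay is expected at best, with a substantial chance that no number is obtained. Compound 3 is estimated in this assay at 35000 nM, with a range from 10000 nM to 150000 nM.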

Compound 3, half-maximal inhibitory concentration: "not active" (no number reported)
Nothing numeric was reported for compound 3; there is nothing to compare the estimate with.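

In this assay compound 2 gives "not active" (no number reported) and compound 3 gives "not active" (no number reported), so no step can be read between these two compounds. The compounds shown leave open whether hydroxymethyl in place of carboxy changes the result at all on this chain. No measured evidence bearing on this result is available.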